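This account rests on a few compounds, and the source may have more. Where it says the series, first, only, none or still open, it means among the compounds named here.

Measured so far in a functional assay on 143B cells (Homo sapiens) for antiproliferative activity, read by MTT assay, with a stated time of 48 h; on this read-out lower numbers stand for stronger inhibition and higher numbers for weaker inhibition: compound 1 `Cc1ccccc1C(=O)Nc1cccc(/C=C/C(=O)c2nc3ccccc3[nH]2)c1` gives 8290 nM; compound 2 `O=C(/C=C/c1cccc(NS(=O)(=O)c2cccc(Cl)c2)c1)c1nc2ccccc2[nH]1` gives 2510 nM; compound 3 `O=C(/C=C/c1cccc(NS(=O)(=O)c2ccc(Cl)cc2)c1)c1nc2ccccc2[nH]1` gives 7450 nM.

Compound 3 stands second highest of these three numbers; its number and that of compound 1 lie within the scatter of each other, while the step of a 3.0-fold higher number from compound 2 to compound 3 (0.47 log units; beyond the scatter) lies beyond it. Compound 4 `Cc1cccc(S(=O)(=O)Nc2cccc(/C=C/C(=O)c3nc4ccccc4[nH]3)c2)c1` differs from compound 3 by 3-methylphenyl in place of 4-chlorophenyl on a sulfonyl sulfur. For the measured compounds named here, only one measured step bears on this change, the one where a 3-chlorophenyl group gave a lower number than a 4-chlorophenyl group, a 3.0-fold higher number from compound 2 to compound 3 (0.47 log units; beyond the scatter). Going by the values given here, no measured pair shows methyl against chlorine. Compound 4 is therefore expected to show a modest decrease in the number, a 1.9-fold lower number from compound 3 to compound 4 (0.27 log units; within the scatter), with considerable uncertainty. The estimate for compound 4 in this assay is 4000 nM, between 1500 nM and 11000 nM.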

Compound 4, half-maximal inhibitory concentration: 791 nM
The estimate for compound 4 lay 5.1-fold (0.70 log units) above the measured number; measured number below the stated range.
By their numbers in this assay, from the lowest: compound 4; then compound 2; then compounds 3 and 1 (each within the scatter of the next).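

On the sulfonyl sulfur, swapping one ring group of equal size for another can shift the number substantially (a 9.4-fold lower number from compound 3 to compound 4 (0.97 log units; beyond the scatter)). The earlier compounds shown here showed only the effect of moving chlorine, whereas the change from chloro to methyl on an aromatic carbon shows that the substituent's identity also matters (a 3.2-fold lower number from compound 2 to compound 4 (0.50 log units; beyond the scatter)). The (3-methylphenyl)sulfonyl group also gives the largest step from the (2-methylphenyl)carbonyl compound (a 10-fold lower number from compound 1 to compound 4 (1.02 log units; beyond the scatter)).

From the compounds shown here alone, whether 4-methylphenyl or 3-methoxyphenyl on the sulfonyl sulfur would keep this gain stays open. Nothing available explains why methyl gives the lower number here.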